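The compounds below may be only part of what the source reports. "The series", "measured", "known", "first", "only" and "open" are said of these compounds alone.

Compound 1 `COCCNc1nc(F)c(-c2nn(Cc3ccc(C#N)cc3)c(=O)c3ccccc23)cc1Cl`: > 100000 nM, a limit
Compound 2 `Cc1cc(-c2ccc(F)nc2F)nn(Cc2ccc(Cl)cc2)c1=O`: 83800 nM
Compound 3 `Cc1ccc(-c2nn(Cc3ccc(C#N)cc3)c(=O)c3ccccc23)c(F)n1`: > 100000 nM, a limit

In an ADME assay on HepG2 2.2.15 cells (Homo sapiens) for cytotoxicity, read by MTT assay, with a stated time of 8 days (a higher number here means that more compound is tolerated, a lower number that less compound is tolerated), compound 1 reaches only a limit, > 100000 nM. Compound 3 likewise gives only a limit, > 100000 nM. Among the measured compounds shown here, compound 2 is the one compound of the three with a measured number, 83800 nM, while the other two sit at the limit of > 100000 nM in this assay, at which 2 of the 3 values shown sit. For the measured compounds named here, no two measured compounds differ in a single place, so no measured step exists in this set. Compound 4 `O=c1c(C2CC2)cc(-c2ccc(F)nc2F)nn1Cc1ccc(Cl)cc1` is the next compound to be measured in this assay. Relative to compound 2 the change is cyclopropyl in place of methyl on an aromatic carbon. Going by the values given here, with no measured step to lean on, the expected step from compound 2 to compound 4 in this assay is a 1.2-fold lower number from compound 2 to compound 4 (0.08 log units; within the scatter), no more than the usual scatter. Compound 4 is therefore estimated at 70000 nM, with a range from 30000 nM to 150000 nM.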

Compound 4, half-maximal cytotoxic concentration: 39800 nM
Compound 4: the middle estimate sits 1.8-fold (0.25 log units) above what was measured, within the range that was stated.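

In this assay, the position opposite the ring nitrogen proves sensitive to its substituent: cyclopropyl in place of methyl gives a 2.1-fold lower number from compound 2 to compound 4 (0.32 log units; beyond the scatter). Among the compounds shown here, this is the first measured step, and it rests on a single pair, which shows the direction of the change but not its cause. Compounds 1 and 3 differ from these two in more than one place and give no number for comparison: the limit of > 100000 nM in this assay, at which 2 of the 4 values shown sit.

Going by these compounds, whether ethyl, methoxy or an amine at this position would also lower the number remains open. So does whether the same change would give a similar step with the nitrile-bearing benzyl group of compounds 1 and 3.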